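The compounds below may be only part of what the source reports. "The series", "measured", "known", "first", "only" and "open" are said of these compounds alone.

Compound 1 `O[C@@H]1[C@@H](O)[C@H](Oc2ccc(S)c3ccccc23)OC[C@H]1O` — 55 uM
Compound 2 `O[C@@H]1[C@@H](O)[C@H](Oc2ccc3cc(S)ccc3c2)OC[C@H]1O` — 135 uM
Compound 3 `CCCSc1ccc(O[C@@H]2OC[C@@H](O)[C@H](O)[C@H]2O)c2ccccc12` — 30 uM

These three compounds were tested in a functional assay on T-24 cells (Homo sapiens) for antiproliferative activity, read by crystal violet staining, with a stated time of 96 h; on this read-out lower numbers stand for an effect already at smaller amounts and higher numbers for an effect only at larger amounts of compound. Compound 3 differs from compound 1 in one place: propyl in place of hydrogen on a sulfur. This step gave a 1.8-fold lower number from compound 1 to compound 3 (0.26 log units; within the scatter). Compound 2 is built from the same atoms as compound 1, joined differently; the difference between the two cores is not broken down here. Compound 2 stands highest of the three numbers.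

Compound 4 `CCCSc1ccc2cc(O[C@@H]3OC[C@@H](O)[C@H](O)[C@H]3O)ccc2c1` has not yet been measured. It stands to compound 2 as compound 3 stands to compound 1: propyl in place of hydrogen on a sulfur. The surroundings of the change read the same in both pairs, a sulfur whose other neighbour is an aromatic carbon, so this is the same change. Compound 4 is expected to show a 1.8-fold lower number from compound 2 to compound 4 (0.26 log units; within the scatter), because the earlier step was a 1.8-fold lower number from compound 1 to compound 3 (0.26 log units; within the scatter). Compound 4 is therefore estimated at 75 uM, with a range from 35 uM to 150 uM.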

Compound 4, concentration for half-maximal effect: 40 uM
Beside the measured number, compound 4's estimate is 1.9-fold (0.27 log units) above it, and the stated range covers the measured number.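

In this assay, propyl in place of hydrogen on the sulfur gave a 3.4-fold lower number from compound 2 to compound 4 (0.53 log units; beyond the scatter). Set beside the same change on the other core, the two steps cannot be told apart: the same change on two cores in this assay, a 1.8-fold lower number (0.26 log units; within the scatter) from compound 1 to compound 3 and a 3.4-fold lower number (0.53 log units; beyond the scatter) from compound 2 to compound 4, 1.8-fold (0.27 log units) apart, within the scatter of two such steps. For the compounds shown here, this shows that the change carried over between these two cores without a clear difference in size, but only the step on the core of compound 2 stands clear of the scatter, and two cores in one assay do not show how it would behave on any other core.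

On these data alone, it remains open how a longer chain, such as hexyl, would compare with propyl on the sulfur. As far as these compounds go, the effect of a propyl chain carrying an amine or a carboxylic acid is also open.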